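Swapping chloro for methyl on the sulfonamide aryl ring

The source may hold more compounds than are shown below. What is called first, only, known or untested is meant among the compounds shown, and "the series" means these compounds.

Compound 1, `COc1cc(Cl)ccc1S(=O)(=O)Nc1cccnc1`, is examined in an assay on isolated protein for inhibition of alkaline phosphatase, tissue-nonspecific isozyme (Homo sapiens) (a lower number here means a stronger inhibitor, a higher number a weaker inhibitor), where compound 1 gives 4170 nM. Of the three numbers at hand, that of compound 1 is the highest. Compound 2, `COc1ccc(C(F)(F)F)cc1S(=O)(=O)Nc1cccnc1`, gives 183 nM in this assay, and compound 3, `COc1ccc(F)cc1S(=O)(=O)Nc1cncc(C(N)=O)c1`, gives 19 nM; both of these stand beyond the scatter below the value of compound 1, so compound 1 is the weakest inhibitor among the three measured compounds. Neither compound 2 nor compound 3 differs from compound 1 in one place alone, so their values are read only as they stand.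

The unmeasured compound 4, `COc1cc(C)ccc1S(=O)(=O)Nc1cccnc1`, differs from compound 1 in one place: methyl in place of chloro on an aromatic carbon. The rest of the shared core is unchanged. For the measured compounds named here, no pair of measured compounds shows this kind of swap, so nothing measured here tells how large its effect will be. The step from compound 1 to compound 4 is expected to be small and within the scatter, a 1.2-fold higher number from compound 1 to compound 4 (0.08 log units; within the scatter). For compound 4 the value in this assay is estimated at 5000 nM, with a range from 1500 nM to 16000 nM.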

Compound 4, half-maximal inhibitory concentration: 896 nM
The estimate for compound 4 lay 5.6-fold (0.75 log units) above the measured number; measured number outside the range, below it.
By their numbers in this assay, from the lowest: compound 3; then compound 2; then compound 4; then compound 1.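

The carbon para to a large group and meta to a methoxy group proves sensitive to substitution: in this assay, methyl in place of chloro gives a 4.7-fold lower number from compound 1 to compound 4 (0.67 log units; beyond the scatter), a modest step. The change leaves the heavy-atom count the same and adds no hydrogen-bond donor, hydrogen-bond acceptor or net charge, so these counts alone do not set the number at this position. For the compounds shown here, no earlier pair could show this. None of them differed in one place. Nothing available explains why methyl gives the lower number here.

As far as these compounds go, whether an ethyl group, an amine or a carboxylic acid on this same carbon would lower the number further or raise it remains open. Also open, from the compounds shown here alone, is whether the swap would give a step of similar size on a core carrying a different group in place of the unsubstituted pyridine portion of compound 1.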